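This account rests on a few compounds, and the source may have more. Where it says the series, first, only, none or still open, it means among the compounds named here.

Working notes on the series. Compound 1 `CCOC(=O)c1cnn(CC(O)CC)c1NC(=O)NC(C)C` carries an isopropyl on the amide-type nitrogen. In a functional assay on cells (Neutrophil, Homo sapiens) for inhibition, with a stated time of 10 min (on this read-out lower numbers stand for stronger inhibition and higher numbers for weaker inhibition), compound 1 gives > 10 nM, which is a limit of the assay rather than a number (the limit of > 10 nM in this assay, at which 1 of the 3 values shown sits). Compound 2 `CCCC(O)Cn1ncc(C(=O)OCC)c1NC(=O)NC(C)C` gives 20 nM in this assay, and compound 3 `CCOC(=O)c1cnn(C)c1NC(=O)NC(C)C` gives 77 nM. The steps a step that the limit leaves unreadable from compound 1 to compound 2 and a step that the limit leaves unreadable from compound 1 to compound 3 cannot be sized, while a 3.9-fold higher number from compound 2 to compound 3 (0.59 log units; beyond the scatter) is readable. Compound 4 `CCOC(=O)c1cnn(CC(O)CC)c1NC(=O)Nc1cccc(F)c1` differs from compound 1 by 3-fluorophenyl in place of isopropyl on an amide-type nitrogen. For the measured compounds named here, no measured step touches the amide-type nitrogen, and both steps leaving compound 1 are unreadable, so no direction beyond the scatter is expected for a step that the limit leaves unreadable from compound 1 to compound 4. Compound 4 is estimated at 30 nM in this assay, within 5 nM to 200 nM.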

Compound 4, half-maximal inhibitory concentration: 0.19 nM
Estimate against measurement, compound 4: 160-fold (2.20 log units) above, and the stated range ends above it.
By their numbers in this assay, from the lowest: compound 4; then compound 2; then compound 3.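

For the compounds shown here, replacing isopropyl with 3-fluorophenyl on the amide-type nitrogen gives, in this assay, an at least 52-fold lower number from compound 1 to compound 4 (1.72 log units; beyond the scatter), the first readable step leaving compound 1 and the first change at this position, which proves highly responsive. The earlier steps shown here leaving compound 1 cannot be read. Compound 1 stands at a limit and not at a number: the limit of > 10 nM in this assay, at which 1 of the 4 values shown sits.

It remains open whether the step belongs to the aromatic ring or to the fluorine, since a plain phenyl or a cyclohexyl on this nitrogen is not among the compounds shown. Also open, as far as these compounds go, is whether 3-fluorophenyl gives a similar step on the core of compound 2 or compound 3.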